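The source may hold more compounds than are shown below. What is called first, only, known or untested is meant among the compounds shown, and "the series" means these compounds.

Compound 1, `O=C(COc1ccc2cc(/C=C3/SC(=O)NC3=O)ccc2c1)Nc1cccc(Cl)c1`, is a thiazolidinedione-bearing naphthyl ether whose amide nitrogen carries a 3-chlorophenyl group. In an assay on isolated protein for inhibition of histone deacetylase 8 (Homo sapiens), with a stated time of 1 h (on this read-out lower numbers stand for stronger inhibition and higher numbers for weaker inhibition), compound 1 gives only a limit, > 50000 nM, and no number; on the numbers shown it is the one compound of the three that sits outside the measured range, because the limit of > 50000 nM in this assay, at which 1 of the 3 values shown sits, is where its value stands.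

Two neighbours differ from compound 1 only in the group on the amide nitrogen. Compound 2, `O=C(COc1ccc2cc(/C=C3/SC(=O)NC3=O)ccc2c1)Nc1ccc(F)cc1`, gives 6600 nM in this assay, and the step of an at least 7.5-fold lower number from compound 1 to compound 2 (0.87 log units; beyond the scatter) is the result. Compound 3, `COc1cccc(NC(=O)COc2ccc3cc(/C=C4/SC(=O)NC4=O)ccc3c2)c1`, gives 7600 nM, with the step of an at least 6.5-fold lower number from compound 1 to compound 3 (0.81 log units; beyond the scatter). Between these two, a 1.2-fold higher number from compound 2 to compound 3 (0.06 log units; within the scatter) shows nothing that can be told apart.

Compound 4, `Cc1cc(NC(=O)COc2ccc3cc(/C=C4/SC(=O)NC4=O)ccc3c2)no1`, has not yet been measured. Its difference from compound 1 is 5-methyl-1,2-oxazol-3-yl in place of 3-chlorophenyl on an amide-type nitrogen. Both measured steps out of compound 1 change the same amide-nitrogen aryl group and both lower the number, so a downward step is expected here as well: compound 4 is estimated to lie at 12000 nM, within 3000 nM to 50000 nM. That estimate corresponds to an expected step of an at least 4.1-fold lower number from compound 1 to compound 4 (0.61 log units; beyond the scatter), though a limit from compound 4 as well cannot be excluded.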

Compound 4, half-maximal inhibitory concentration: > 50000 nM
Compound 4 was reported as a limit; the forecaster's own chance of this, stated with the estimate: 30%; middle value at least 4.1-fold (0.61 log units) from the limit.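

Unlike the 4-fluorophenyl group of compound 2 and the 3-methoxyphenyl group of compound 3, the 5-methyl-1,2-oxazol-3-yl group of compound 4 gives no measured number in this assay, so replacing the 3-chlorophenyl group does not by itself bring a compound of this series into the measured range. Against those two neighbours, the change on the amide-type nitrogen gives an at least 6.5-fold higher number from compound 3 to compound 4 (0.81 log units; beyond the scatter) and an at least 7.5-fold higher number from compound 2 to compound 4 (0.87 log units; beyond the scatter), which shows that the outcome at this position depends on which group enters, and that two different aryl groups can fall on the same side of the limit. The step between compound 1 and compound 4 cannot be read, because both are reported as a limit and not as a number: the limit of > 50000 nM in this assay, at which 2 of the 4 values shown sit.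

The compounds shown leave open whether the result for compound 4 goes with the five-membered aromatic ring or with its methyl group, a question that a 1,2-oxazol-3-yl group without the methyl or a plain phenyl group on the same nitrogen would address. They also leave open whether compound 1 and compound 4 differ from each other at all, and whether the 4-chlorophenyl group would behave like the 3-chlorophenyl or the 4-fluorophenyl group.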